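Sulfonyl substituent trimming in a phenylacetylene aryloxyacetic acid series

The source may hold more compounds than are shown below. What is called first, only, known or untested is meant among the compounds shown, and "the series" means these compounds.

Three measured compounds share a core of a chlorinated aryloxyacetic acid linked through an alkyne to a second aromatic ring. Compound 1 `CC(C)S(=O)(=O)c1ccc(Cl)c(C#Cc2cc(Cl)ccc2OCC(=O)O)c1` carries an isopropylsulfonyl group and gives 2.9 nM in an assay on CHO cells for displacement of a labelled ligand from prostaglandin D2 receptor 2 (Homo sapiens), read by scintillation counting; on this read-out higher numbers stand for weaker inhibition and lower numbers for stronger inhibition. Compound 2 `COCc1ccc(F)c(C#Cc2cc(Cl)ccc2OCC(=O)O)c1` gives 72 nM in this assay, and compound 3 `CCCCCCc1ccncc1C#Cc1cc(Cl)ccc1OCC(=O)O` gives 43 nM. Compound 1 therefore has the lowest number of the three, and both gaps, to compound 3 and to compound 2, lie beyond the scatter of repeated measurements, so compound 1 counts as the most potent of the measured set.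

Compound 4 `CS(=O)(=O)c1ccc(Cl)c(C#Cc2cc(Cl)ccc2OCC(=O)O)c1` differs from compound 1 in one place: methyl in place of isopropyl on a sulfonyl sulfur, that is, isopropylsulfonyl to methylsulfonyl. Going by the values given here, no pair of measured compounds shows this change, so its size is not known from the set. A small step is expected, if anything toward a slightly higher number, but not clearly beyond the scatter. The step from compound 1 to compound 4 is estimated at a 1.7-fold higher number from compound 1 to compound 4 (0.24 log units; within the scatter). Compound 4 is accordingly expected to give 5 nM in this assay, with a range of 1.5 nM to 16 nM.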

Compound 4, inhibition constant: 3.5 nM
Compound 4: the middle estimate sits 1.4-fold (0.15 log units) above what was measured; measured number inside the range.
By their numbers in this assay, from the lowest: compounds 1 and 4 (each within the scatter of the next); then compounds 3 and 2 (each within the scatter of the next).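

Trimming the alkyl group on the sulfonyl sulfur gives a 1.2-fold higher number from compound 1 to compound 4 (0.08 log units; within the scatter) in this assay, the first reading in this series of a change in one place. At this position, isopropyl and methyl cannot be told apart on this read-out, so the low number of compound 1 does not depend on isopropyl in particular, and compound 4 keeps it with the smaller methyl. The compounds shown offer no measured basis for explaining this flat step.

Open, on these data alone, is how far this tolerance extends on the sulfonyl sulfur, for example to a longer chain such as n-butyl, a cyclopropyl ring or an amine. Also open, as far as these compounds go, is whether the sulfonyl group itself is needed, which a carbonyl or a nitrile in its place on the shared core would test.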